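The source may hold more compounds than are shown below. What is called first, only, known or untested is meant among the compounds shown, and "the series" means these compounds.

In a functional assay on CNE-2 cells (Homo sapiens) for antiproliferative activity, read by sulforhodamine B assay, with a stated time of 48 h (a higher number here means a weaker inhibitor, a lower number a stronger inhibitor), compound 1 (`COc1ccc(/C=C/C(=O)c2ccccc2-c2ccc(F)cc2)cc1`) gives 53 nM, compound 2 (`COc1ccc(/C=C/C(=O)c2ccccc2-c2ccc(F)cc2)cc1OC`) gives 81 nM and compound 3 (`COc1ccc(/C=C/C(=O)c2ccccc2-c2ccc(F)cc2)cc1B(O)O`) gives 21 nM. Compound 1 therefore cannot be separated from the methoxy analogue, with a 1.5-fold higher number from compound 1 to compound 2 (0.18 log units; within the scatter), but it does stand apart from the boron-bearing analogue, with a 2.5-fold lower number from compound 1 to compound 3 (0.40 log units; beyond the scatter). The remaining pair shows a 3.9-fold lower number from compound 2 to compound 3 (0.59 log units; beyond the scatter).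

Compound 4 (`COc1ccc(/C=C/C(=O)c2ccccc2-c2cccnc2)cc1`) changes a different place: pyridin-3-yl in place of 4-fluorophenyl on an aromatic carbon. Among the measured compounds shown here, none of the measured steps touches the 4-fluorophenyl group, so the series holds no direct precedent for this swap. For the measured compounds named here, they show only that single changes elsewhere on compound 1 have so far stayed modest, the larger being a 2.5-fold lower number from compound 1 to compound 3 (0.40 log units; beyond the scatter). A step of similar or smaller size is therefore expected in this assay, with a weak lean towards a higher number and no firm support for either direction. The estimated step is a 1.7-fold higher number from compound 1 to compound 4 (0.23 log units; within the scatter). Compound 4 is expected at 90 nM, with an estimated range of 25 nM to 300 nM.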

Compound 4, half-maximal inhibitory concentration: 64 nM
The estimate for compound 4 lay 1.4-fold (0.15 log units) above the measured number; measured number inside the range.
By their numbers in this assay, from the lowest: compound 3; then compounds 1, 4 and 2 (each within the scatter of the next).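

In this assay the place held by 4-fluorophenyl, on an aromatic carbon ortho to a large group, accepts pyridin-3-yl with a 1.2-fold higher number from compound 1 to compound 4 (0.08 log units; within the scatter), so this ring exchange cannot be separated from no change. The series now shows that the fluorine and the carbon-only ring can both be replaced at once without a step beyond the scatter, though this rests on a single pair. No supporting data bear on the reason for this result.

Open, on these data alone, is whether the ring nitrogen and the loss of fluorine each leave the number unmoved, which plain phenyl in the same place would help to separate, and how an aminomethyl group or a carboxylic acid on this ring would read. Also open, as far as these compounds go, is whether the boron-bearing group of compound 3 keeps its effect, seen in a 2.5-fold lower number from compound 1 to compound 3 (0.40 log units; beyond the scatter), when combined with pyridin-3-yl.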